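A few compounds are considered here, and "the series" means these few. Any claim that something is new, unique, unknown or untested is made for them only; others in the source may bear on it.

Measured compounds:
compound 1, `O=C(Nc1cccc(-c2oc3cc(-c4ccc(F)cc4)ccc3c(=O)c2O)c1)c1ccc(F)cc1`, 14600 nM
compound 2, `O=C(Nc1cccc(-c2oc3cc(-c4ccc(F)cc4)ccc3c(=O)c2O)c1)c1ccc(C(F)(F)F)cc1`, 33000 nM

Both numbers come from a functional assay on GTL 16 cells for antiproliferative activity against GTL 16 cell line (Homo sapiens), read by CCK-8 assay, with a stated time of 72 h; on this read-out higher numbers stand for weaker inhibition and lower numbers for stronger inhibition. Compound 1 stands as the lowest of the two numbers, and its nearest neighbour is compound 2, with a shift of a 2.3-fold higher number from compound 1 to compound 2 (0.35 log units; beyond the scatter). The unmeasured compound 3, `O=C(Nc1cccc(-c2oc3cc(-c4ccc(F)cc4)ccc3c(=O)c2O)c1)c1cc(F)cc(F)c1`, differs from compound 1 by 3,5-difluorophenyl in place of 4-fluorophenyl on a carbonyl carbon. Among the measured compounds shown here, the only step that bears on this change is the one from compound 1 to compound 2, a 2.3-fold higher number from compound 1 to compound 2 (0.35 log units; beyond the scatter), which also alters the fluoro-bearing ring on the carbonyl carbon, yet it exchanges fluoro for trifluoromethyl rather than replacing 4-fluorophenyl with 3,5-difluorophenyl, so it is an imperfect guide. For compound 3 one would therefore expect in this assay a step of a 1.2-fold higher number from compound 1 to compound 3 (0.09 log units; within the scatter), which stays inside the scatter. The estimate for compound 3 is 18000 nM, with a range from 7000 nM to 45000 nM.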

Compound 3, half-maximal inhibitory concentration: 7410 nM
Compound 3: the middle estimate sits 2.4-fold (0.39 log units) above what was measured, within the range that was stated.
By their numbers in this assay, from the lowest: compounds 3 and 1 (each within the scatter of the next); then compound 2.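

In this assay, moving from 4-fluorophenyl to 3,5-difluorophenyl on the carbonyl carbon gives a 2.0-fold lower number from compound 1 to compound 3 (0.29 log units; within the scatter), so this change does not separate the two compounds. The comparison with the trifluoromethyl analogue does show a separation, with a 4.5-fold lower number from compound 2 to compound 3 (0.65 log units; beyond the scatter). The weaker inhibition seen earlier with 4-(trifluoromethyl)phenyl therefore does not extend to every change in fluorine substitution on this ring, and a second fluoro is accommodated here with no loss beyond the scatter.

The compounds shown leave open whether this position needs fluorine at all, and how an unsubstituted phenyl, or a phenyl bearing an amine or a carboxylic acid, would read out. Nothing available here accounts for these differences.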